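Cyclohexylamino in Place of a Carboxycyclopentenyl Group

A few compounds are considered here, and "the series" means these few. Any claim that something is new, unique, unknown or untested is made for them only; others in the source may bear on it.

Compound 1, `CCCn1c(=O)c2nc(C3CCC(C(=O)N(C)CCN(C)C)CC3)[nH]c2n(CCC)c1=O`, gives 17 nM; 85 nM (2 entries) in a functional assay for antagonist activity at adenosine receptor A1 (Homo sapiens); a lower number here means a stronger inhibitor, a higher number a weaker inhibitor.
Compound 2, `CCCn1c(=O)c2nc(C3=C(C(=O)O)CCC3)[nH]c2n(CCC)c1=O`, gives in this assay only > 10000 nM, which is a limit of the measurement and not a number.

Compound 2 therefore stands at the edge of what this assay can report, and a further entry for it likewise gives no single value. Compound 1, by contrast, is supported by several entries (the several entries of compound 1 in this assay, 17 nM; 85 nM (2 entries)). Compound 3, `CCCn1c(=O)c2nc(NC3CCCCC3)[nH]c2n(CCC)c1=O`, has not yet been measured. It differs from compound 2 in one place: cyclohexylamino in place of 2-carboxycyclopent-1-en-1-yl on an aromatic carbon. Among the measured compounds shown here, no step between two measured compounds is given here, and because compound 2 rests at the limit (the limit of > 10000 nM in this assay, at which 1 of the 2 values shown sits), no measured number tells how far this replacement can reach. What the two measured compounds do show is that a six-membered saturated carbon ring carried on the shared core, as in compound 1, is compatible with inhibition in this assay. The step expected from compound 2 to compound 3 is accordingly a gain well beyond the usual scatter, an at least 100-fold lower number from compound 2 to compound 3 (2.00 log units; beyond the scatter). For compound 3 the estimated inhibition constant in this assay is 100 nM, with a plausible range from 15 nM to 800 nM.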

Compound 3, inhibition constant: 14 nM
For compound 3 the middle estimate is 7.1-fold (0.85 log units) above the measured one, outside the stated range (below it).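

At this aromatic carbon between two ring nitrogen atoms, the change from 2-carboxycyclopent-1-en-1-yl to cyclohexylamino in this assay gives an at least 710-fold lower number from compound 2 to compound 3 (2.85 log units; beyond the scatter), so a ring carried through an amino nitrogen is compatible with inhibition at this position. Compound 3 gives 14 nM, a single number, and this gives the series a second measured compound with a six-membered carbon ring at this place. Compound 2 gives > 10000 nM, which is a limit of the assay and not a number, so the step is a minimum and its full size cannot be read.

The step changes the carboxylic acid, the ring size and the atom joining the ring to the core all at once, and the compounds shown do not tell which of these changes carries the gain. A cyclopentylamino group, or a cyclohexylamino group bearing a carboxylic acid, would begin to separate these changes.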